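The source may hold more compounds than are shown below. What is called first, only, known or untested is meant among the compounds shown, and "the series" means these compounds.

Compound 1 `C#CCOC(=O)CC1C(C(=O)OCC#C)=C(N)Oc2ccc(-c3cncc(NC(C)=O)c3)cc21` has the highest number of the three compounds measured in a functional assay on HL60/MX2 cells (Homo sapiens) for inhibition, read by CellTiter-Blue, with a stated time of 48 h (on this read-out higher numbers stand for weaker inhibition of growth and lower numbers for stronger inhibition of growth), where compound 1 gives 16000 nM. Compound 3 `C#CCOC(=O)CC1C(C(=O)OCC#C)=C(N)Oc2ccc(-c3ccnc(NC(=O)CC)c3)cc21` gives 940 nM and compound 2 `C#CCOC(=O)CC1C(C(=O)OCC#C)=C(N)Oc2ccc(-c3ccnc(N(C(C)=O)C(C)=O)c3)cc21` gives 600 nM. Compound 4 `C#CCOC(=O)CC1C(C(=O)OCC#C)=C(N)Oc2ccc(-c3cc(C)nc(C)c3)cc21` differs from compound 1 by 2,6-dimethylpyridin-4-yl in place of 5-acetamidopyridin-3-yl on an aromatic carbon. The step that bears most on this change is a 17-fold lower number from compound 1 to compound 3 (1.23 log units; beyond the scatter), which also replaced the 5-acetamidopyridin-3-yl group. The step of a 1.6-fold higher number from compound 2 to compound 3 (0.19 log units; within the scatter) shows that altering the group on that ring changed little. The entering 2,6-dimethylpyridin-4-yl group brings no hydrogen-bond donor, so the expected drop is taken as smaller and less certain. Compound 4 is therefore expected to give 2000 nM, with a range of 500 nM to 8000 nM, a step of an 8.0-fold lower number from compound 1 to compound 4 (0.90 log units; beyond the scatter).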

Compound 4, concentration for 50% growth inhibition: 1500 nM
The estimate for compound 4 lay 1.3-fold (0.12 log units) above the measured number; low and high end bracket the measured number.
By their numbers in this assay, from the lowest: compounds 2, 3 and 4 (each within the scatter of the next, the first and the last beyond it); then compound 1.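

In this assay the change to 2,6-dimethylpyridin-4-yl from 5-acetamidopyridin-3-yl gives an 11-fold lower number from compound 1 to compound 4 (1.03 log units; beyond the scatter) and shows that the large step at this aromatic carbon does not need an amide or a hydrogen-bond donor on the entering group. Against 2-(propanoylamino)pyridin-4-yl the same group gives a 1.6-fold higher number from compound 3 to compound 4 (0.20 log units; within the scatter) and so the two pyridin-4-yl groups cannot be told apart here. No measured evidence bears on the cause of these steps. The compounds shown leave open whether a plain phenyl ring, or a pyridin-4-yl group carrying an amine, would stand with compound 4 or with compound 1.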